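Replacing the methoxy group of compound 2 with hydrogen

This account rests on a few compounds, and the source may have more. Where it says the series, first, only, none or still open, it means among the compounds named here.

Measured so far in a functional assay on PC-3 cells (Homo sapiens) for inhibition, read by sulforhodamine B assay, with a stated time of 48 h, tested at 10 uM; a higher number here means more inhibition of growth at the concentration tested, a lower number less inhibition of growth:
Compound 1 `C/C(=N\O)c1ccc(NC(=O)Cn2nc(-c3ccc(Cl)cc3)nc2N)cc1` gives 28.9%
Compound 2 `COc1ccc(-c2nc3sc(-c4ccccc4)cn3n2)cc1` gives 33%

Compound 2 and compound 1 lie within the usual scatter of each other in this assay, so the two numbers do not separate them. Within the data shown here, their structures also differ in more than one place, and no measured pair of compounds differing in one place is available as a guide.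

The next compound is compound 3 `c1ccc(-c2nc3sc(-c4ccccc4)cn3n2)cc1`, which has not yet been measured. It departs from compound 2 in a single place: hydrogen in place of methoxy on an aromatic carbon. In words, this is hydrogen in place of methoxy on an aromatic carbon, and the rest of the structure stays the same.

Among the measured compounds shown here, with no measured step for this change, the data do not show what removing the methoxy group does. For the measured compounds named here, the only anchor is compound 2 with 33%, so a small decrease in this assay is expected, most likely not beyond the scatter. The estimated change is a number 6 percentage points lower from compound 2 to compound 3 (within the scatter), and it remains uncertain in size and direction. For compound 3 the expected value is 27% (range 12% to 42%).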

Compound 3, percent growth inhibition at one concentration: 37%
Beside the measured number, compound 3's estimate is 10 percentage points below it, within the range that was stated.
By their numbers in this assay, from the lowest: compounds 1, 2 and 3 (each within the scatter of the next).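

Within this assay, the one measured step at this position is a number 4 percentage points higher from compound 2 to compound 3 (within the scatter). With the methoxy group on the six-membered aromatic ring, para to a large group, replaced by hydrogen, the two compounds are not separated, so growth inhibition at the concentration tested does not depend on the methoxy group in this pair, something the comparison of compound 1 and compound 2 could not show because those two differ in more than one place. No supporting evidence bears on this result, and the data offer no explanation for it.

The compounds shown carry only methoxy or hydrogen at this position, so it remains open what an amine, a carboxylic acid, a chlorine atom or a longer chain such as butoxy would do there. From the compounds shown here alone, it also remains open whether the same replacement would give a similar result on the core of compound 1, or whether a group added to the other aromatic ring of compound 3 would move its number beyond the usual scatter.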